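This account rests on a few compounds, and the source may have more. Where it says the series, first, only, none or still open, it means among the compounds named here.

Measured compounds:
compound 1 `CCCCCCCCc1ccc(OCC(=O)Cn2nnc(-c3cccc(Cl)c3)n2)cc1`: 24 nM
compound 2 `CCCCCCCCc1ccc(OCC(=O)Cn2nnc(-c3cccnc3)n2)cc1`: 23 nM

In an assay on microsomes from brain for inhibition of Fatty-acid amide hydrolase 1 (Rattus norvegicus), read by fluorescence and HPLC, with a stated time of 60 min (on this read-out lower numbers stand for stronger inhibition and higher numbers for weaker inhibition), compound 2 gives 23 nM, the lower of the two numbers, though its gap to compound 1 is within the scatter. Compound 3 `CCCCCCCCc1ccc(OCC(=O)Cn2nnc(-c3ccc(C(=O)O)cc3)n2)cc1` differs from compound 2 by 4-carboxyphenyl in place of pyridin-3-yl on an aromatic carbon. Within the data shown here, the only measured step that bears on this change is the aryl swap a 1.0-fold lower number from compound 1 to compound 2 (0.02 log units; within the scatter), which showed nothing beyond the scatter; no step on a carboxylic acid exists. Because the step of a 1.0-fold lower number from compound 1 to compound 2 (0.02 log units; within the scatter) was flat, compound 3 is expected to shift only modestly, a 1.7-fold higher number from compound 2 to compound 3 (0.24 log units; within the scatter), with the wide range reflecting the absent precedent. Compound 3 is estimated at 40 nM, range 10 nM to 200 nM.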

Compound 3, half-maximal inhibitory concentration: 90 nM
For compound 3 the middle estimate is 2.3-fold (0.35 log units) below the measured one; the measured number falls inside the stated range.
By their numbers in this assay, from the lowest: compounds 2 and 1 (each within the scatter of the next); then compound 3.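

Among these compounds, this position does not tolerate every aryl swap: a 3.9-fold higher number from compound 2 to compound 3 (0.59 log units; beyond the scatter) and a 3.8-fold higher number from compound 1 to compound 3 (0.57 log units; beyond the scatter) are both modest but beyond the scatter, whereas pyridin-3-yl and 3-chlorophenyl stayed within it. 4-Carboxyphenyl is thus the first group here to separate from the others, and the same shift appears from either neighbour. No measured evidence here accounts for this shift.

As far as these compounds go, whether the shift follows the carboxylic acid itself or its place on the phenyl ring remains open. A 3-carboxyphenyl group, a methyl ester or a primary amide would bear on that.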